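The compounds below may be only part of what the source reports. "The series", "measured", "known", "first", "only" and "open" are said of these compounds alone.

Compound 1, with the structure `CCC[C@@H](OC(C)=O)C1=C(Br)C(=C(Br)Br)OC1=O`, has no number of its own yet: in a functional assay on HT-1080 cells (Homo sapiens) for cytotoxicity (a lower number here means that less compound is needed, a higher number that more compound is needed for the effect), compound 1 gives "not determined" (no result reported). Compound 3, `CCC[C@@H](OC(C)=O)C1=C(Br)[C@@](OC)(C(Br)Br)OC1=O`, likewise gives "not determined" (no result reported) in this assay. Within the data shown here, the one reading available comes from compound 2, `CCCCCCC(=O)C(Br)=C(Br)Br`; in this assay compound 2 reaches only a limit of the assay, > 20 ug/mL. Compound 4, `CCCCC1=C(Br)C(=C(Br)Br)OC1=O`, differs from compound 1 by hydrogen in place of acetoxy on a saturated chain carbon bound to a double-bonded ring carbon and a saturated chain carbon. Among the measured compounds shown here, no pair of measured compounds shows what such a change does in this assay, so neither the direction nor the size of the step can be read from the data, and the expectation rests only on (the limit of > 20 ug/mL in this assay, at which 1 of the 3 values shown sits). On that basis compound 4 is expected to come out near 15 ug/mL, within a range from 4 ug/mL to 40 ug/mL.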

Compound 4, concentration for half-maximal effect: > 20 ug/mL
Compound 4: no number, only a limit; the forecaster's own chance of this, stated with the estimate: 50%; middle value at least 1.3-fold (0.12 log units) from the limit.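

Among these compounds, compound 1 has no reported result and compound 4 gives only a limit, so no step between them can be read. Whether exchanging acetoxy for hydrogen matters in this assay stays open, with no exact value among the compounds shown: the limit of > 20 ug/mL in this assay, at which 2 of the 4 values shown sit.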